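Propoxy for fluorophenoxy on the ketone of the series

The source may report more compounds than this note shows. Statements on the series, on what has been measured and on what is new or still open speak of the compounds shown alone.

Measured so far:
compound 1, `COc1cc2c(cc1CC=C(C)C)/C(=N/NC(N)=O)C[C@@H](c1ccc(O)cc1)O2` — 93%
compound 2, `COc1ccc([C@@H]2C/C(=N/OCc3cn(-c4ccccc4CO)nn3)c3cc(CC=C(C)C)c(OC)cc3O2)cc1` — 100%
compound 3, `COc1cc2c(cc1CC=C(C)C)C(=O)C[C@@H](c1ccc(Oc3ccc(F)cc3)cc1)O2` — 37%

In a functional assay on MCF7 cells (Homo sapiens) for inhibition, read by sulforhodamine B assay, with a stated time of 48 h, tested at 50 uM (a higher number here means more inhibition of growth at the concentration tested, a lower number less inhibition of growth), compound 3 stands lowest of the three numbers. Compound 1 lies higher by a margin beyond the scatter, and compound 2 lies higher still, also beyond the scatter. Among the measured compounds shown here, compound 3 is the only ketone of the three measured; the other two carry a hydrazone or an oxime ether in that place, so no pair of measured compounds isolates the effect of the group on the aromatic oxygen.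

Compound 4, `CCCOc1ccc([C@@H]2CC(=O)c3cc(CC=C(C)C)c(OC)cc3O2)cc1`, is the next entry for this assay. Relative to compound 3 the change is propyl in place of 4-fluorophenyl on an oxygen on an aromatic ring. Nothing measured here separates the 4-fluorophenoxy from a smaller alkoxy on the same oxygen, so the step from compound 3 to compound 4 is estimated to be small, within the scatter, with no direction that can be defended from the numbers shown; the estimated step is a number 3 percentage points higher from compound 3 to compound 4 (within the scatter). For compound 4 the expected growth inhibition is 40%, with a range from 15% to 70%, the width reflecting that only one ketone has been measured.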

Compound 4, percent growth inhibition at one concentration: 60%
Compound 4: middle estimate off by 20 percentage points, on the low side; measured number inside the range.
By their numbers in this assay, from the lowest: compound 3; then compound 4; then compounds 1 and 2 (each within the scatter of the next).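

Propyl in place of 4-fluorophenyl on an oxygen on an aromatic ring gives a number 23 percentage points higher from compound 3 to compound 4 (beyond the scatter) in this assay, the first comparison in the series that changes one place only. This shows that the group on this oxygen influences growth inhibition in the ketone and that an aromatic ring there is not required for it, although steps from compound 1 or compound 2 to either ketone cannot be read because those compounds differ in more than one place. Nothing measured on these compounds accounts for the step, and no cause can be assigned to it.

A single pair cannot separate the loss of the 4-fluorophenyl ring from the gain of the propyl chain, and an unsubstituted phenyl, a butyl chain or a longer chain on the same oxygen of the ketone would help to tell these apart. From the compounds shown here alone, it also remains open whether propyl keeps this effect when the carbonyl is replaced by the hydrazone of compound 1 or the oxime ether of compound 2.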